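A few compounds are considered here, and "the series" means these few. Any claim that something is new, unique, unknown or untested is made for them only; others in the source may bear on it.

Measured compounds:
Compound 1 `Cc1cc(C)c2cc(C#N)c(N3CCN(C(=O)c4ccncc4)CC3)nc2c1`: in an assay on cells with Cystic fibrosis transmembrane conductance regulator variant F508del (Homo sapiens) as the target, read by fluorescence, with stated times of 24 h and 30 min (on this read-out lower numbers stand for an effect already at smaller amounts and higher numbers for an effect only at larger amounts of compound), compound 1 gives 100000 nM
Compound 2 `C=CCc1cc(-c2sc(NC(=O)C(C)(C)C)nc2C)nn1C(=O)Nc1ccccc1`: in this assay compound 2 gives 3020 nM
Compound 3 `Fc1ccc(CN2CCc3nc(-c4ccccn4)nc(NCCCN4CCCC4)c3C2)cc1`: in this assay compound 3 gives 200 nM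

Of the three measured compounds, compound 3 stands at the lowest number. The nearest to it is compound 2, whose value lies beyond the scatter of compound 3, and compound 1 lies far beyond it again, so compound 3 is the most potent of the three on the numbers shown. The three share no common core, so none of these gaps can be laid at the door of a single structural change.

Compound 4 `CC(=O)NCCCNc1nc(-c2ccccn2)nc2c1CN(Cc1ccc(F)cc1)CC2` is built on compound 3 with one alteration: acetamido in place of pyrrolidin-1-yl on a saturated chain carbon, three bonds along the chain from a nitrogen on an aromatic ring. Among the measured compounds shown here, no pair of measured compounds shows this kind of exchange, so nothing measured here says how large a step it brings. Without such a reference, the expectation is that the exchange costs some potency, with compound 4 at a higher number than compound 3, a step of moderate size that is expected as a 3.2-fold higher number from compound 3 to compound 4 (0.50 log units; beyond the scatter). For compound 4 the value in this assay is estimated at 630 nM, with a range from 150 nM to 3000 nM.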

Compound 4, half-maximal effective concentration: 200 nM
Beside the measured number, compound 4's estimate is 3.2-fold (0.50 log units) above it; low and high end bracket the measured number.
By their numbers in this assay, from the lowest: compounds 3 and 4 (each within the scatter of the next); then compound 2; then compound 1.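

In this assay, acetamido in place of pyrrolidin-1-yl on a saturated chain carbon, three bonds along the chain from a nitrogen on an aromatic ring, gives no change at the digits printed from compound 3 to compound 4 (within the scatter). Among the compounds shown here, this is the first pair here that differs in one place, and it shows that, on this chain and this core, the five-membered non-aromatic ring can give way to an open group with a double bond and a hydrogen-bond donor without the read-out moving beyond the scatter. Nothing given here explains why the two groups read alike.

Going by these compounds, the result rests on one pair, so it remains open whether this tolerance extends to other end groups on the chain, such as a free primary amine, a dimethylamino group, a morpholin-4-yl ring or a carboxylic acid. On these data alone, it also remains open how a shorter or longer chain carrying the acetamido group would read, and whether the same exchange would read alike on the cores of compound 1 or compound 2.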